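The source may hold more compounds than are shown below. What is called first, only, known or untested is meant among the compounds shown, and "the series" means these compounds.

Measured compounds in an assay on Cerebral cortex for binding affinity to adenosine receptor A1 (Cavia porcellus), read by radioligand binding; a higher number here means a weaker inhibitor, a lower number a stronger inhibitor:
Compound 1, `CCCn1c(=O)n(CC(=O)O)c(=O)c2[nH]cnc21`, gives > 200000 nM, a limit of the assay and not a number.
Compound 2, `CCCn1c(=O)n(CCC(=O)O)c(=O)c2[nH]cnc21`, gives > 200000 nM, again a limit.
Compound 3, `CCCn1c(=O)n(CCCN(C)C)c(=O)c2[nH]cnc21`, gives 43200 nM.

For the measured compounds named here, compound 3 is thus the only member of the series with a numerical reading in this assay; the two carboxylic acids sit at the limit of > 200000 nM in this assay, at which 2 of the 3 values shown sit. The steps from the acids to compound 3 read an at least 4.6-fold lower number from compound 1 to compound 3 (0.66 log units; beyond the scatter) and an at least 4.6-fold lower number from compound 2 to compound 3 (0.66 log units; beyond the scatter), both only lower bounds on the gain. The step that the two limits leave unreadable from compound 1 to compound 2 cannot be read, as both ends are limits.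

Compound 4, `CCCn1c(=O)n(CC(C)=O)c(=O)c2[nH]cnc21`, is not yet measured. It differs from compound 3 by acetyl in place of 2-(dimethylamino)ethyl on a saturated chain carbon bound to an aromatic nitrogen. Going by the values given here, no measured step covers an acetyl on this chain; the only comparisons in hand concern the carboxy and dimethylamino ends, and they show that removing the dimethylamino chain in favour of a carboxy group costs at least a modest amount. Acetyl is neutral, unlike either, so the measured steps give direction only loosely. The expectation is that compound 4 drifts back toward the limit, with an estimated step of a 2.3-fold higher number from compound 3 to compound 4 (0.36 log units; beyond the scatter) in this assay. Compound 4 is therefore expected to give about 100000 nM, within 25000 nM to 200000 nM, with a fair chance that only a limit is reported.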

Compound 4, inhibition constant: 11400 nM
Compound 4: middle estimate off by 8.8-fold (0.94 log units), on the high side; the measured number lies below the stated range.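

In this assay, acetyl in place of 2-(dimethylamino)ethyl on a saturated chain carbon bound to an aromatic nitrogen gives a 3.8-fold lower number from compound 3 to compound 4 (0.58 log units; beyond the scatter), so the earlier ordering, with the dimethylamino end ahead of the carboxy ends, does not make that amine necessary for a numerical reading, and a group with fewer heavy atoms goes further. Measured against the acids, the change is larger, with an at least 17-fold lower number from compound 2 to compound 4 (1.24 log units; beyond the scatter) and an at least 17-fold lower number from compound 1 to compound 4 (1.24 log units; beyond the scatter), which also shows that the carbonyl of compound 4 and the carboxy group of compound 1 do not read alike on this chain. These two steps are lower bounds only, because compound 1 and compound 2 each stand at a limit and not at a number: the limit of > 200000 nM in this assay, at which 2 of the 4 values shown sit.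

From the compounds shown here alone, whether the lower number follows the ketone carbonyl or simply the smaller group stays open, as compound 4 is the only ketone. A plain propyl chain, a methyl ester or a primary amide on the same carbon would separate these two readings, and a longer ketone would show how far the chain can grow.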